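The compounds below may be only part of what the source reports. "The series", "measured", "known", "first", "only" and "open" are said of these compounds alone.

Compound 3 `COc1cc(N)c(Cl)cc1NC(=O)C1CCN(Cc2ccc(F)cc2)CC1` gives 0.6 mg/kg in a functional assay on the whole organism for antagonist activity, with Mus musculus as the target (a higher number here means that more compound is needed for the effect, a lower number that less compound is needed), the lowest number among the values shown. Compound 1 `COc1cc(N)c(Cl)cc1NC(=O)C1CCN(Cc2cccc(C)c2)CC1` gives 2.4 mg/kg in this assay, and a 4.0-fold lower number from compound 1 to compound 3 (0.60 log units; beyond the scatter). For compound 2 `COc1cc(N)c(Cl)cc1NC(=O)C1CCN(C/C=C/c2ccccc2)CC1` the result is only a limit of the assay, > 10 mg/kg. Compound 4 `COc1cc(N)c(Cl)cc1NC(=O)C1CCN(CC2CCCCC2)CC1` differs from compound 3 by cyclohexyl in place of 4-fluorophenyl on a saturated chain carbon bound to an amine nitrogen in a ring. The measured steps all exchange one ring group for another on this carbon, and none brings in a non-aromatic ring; still, a 4.0-fold lower number from compound 1 to compound 3 (0.60 log units; beyond the scatter) and an at least 16-fold lower number from compound 2 to compound 3 (1.22 log units; beyond the scatter) show that exchanges at this place move the number by modest to large amounts. Compound 4 is therefore expected to give a higher number, a 5.0-fold higher number from compound 3 to compound 4 (0.70 log units; beyond the scatter), with an estimate of 3 mg/kg and a range from 0.8 mg/kg to 12 mg/kg.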

Compound 4, dose for half-maximal effect: 2.9 mg/kg
Compound 4: the middle estimate sits 1.0-fold (0.01 log units) above what was measured; the range from low to high includes it.
By their numbers in this assay, from the lowest: compound 3; then compounds 1 and 4 (each within the scatter of the next). At a limit, above all of these: compound 2.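

A non-aromatic ring on this carbon still gives a measured dose in this assay, so an aromatic ring is not needed here, and a 1.2-fold higher number from compound 1 to compound 4 (0.08 log units; within the scatter) leaves cyclohexyl level with 3-methylphenyl. Not every ring matches 4-fluorophenyl, however, as a 4.8-fold higher number from compound 3 to compound 4 (0.68 log units; beyond the scatter) shows. Compound 2 remains a limit, so an at least 3.4-fold lower number from compound 2 to compound 4 (0.53 log units; beyond the scatter) is only a bound: the limit of > 10 mg/kg in this assay, at which 1 of the 4 values shown sits.

Cyclohexyl differs from 4-fluorophenyl both in its ring and in lacking fluorine, and the compounds shown cannot separate these two changes. A plain phenyl or a 4-fluorocyclohexyl group on this carbon would do so.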